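The compounds below may be only part of what the source reports. "The series", "measured", "known", "first", "only" and "open" are said of these compounds alone.

In a functional assay (trachea) with Cavia porcellus as the target (a higher number here means a weaker inhibitor, a lower number a stronger inhibitor), the three measured compounds stand as follows:
compound 1 `CCCn1nc(-c2cccnc2)c2ccccc2c1=O` gives 3160 nM
compound 2 `CCCCn1nc(-c2cccnc2)c2ccccc2c1=O` gives 2290 nM
compound 3 `O=c1c2ccccc2c(-c2cccnc2)nn1C1CCCC1` gives 2750 nM

Compound 3 holds the second highest of the three numbers, with a 1.1-fold lower number from compound 1 to compound 3 (0.06 log units; within the scatter) and a 1.2-fold higher number from compound 2 to compound 3 (0.08 log units; within the scatter); all three sit within the scatter of one another. Compound 4 `O=C(c1cccs1)n1nc(-c2cccnc2)c2ccccc2c1=O` takes the step ((thiophen-2-yl)carbonyl in place of cyclopentyl on an aromatic nitrogen). The measured steps at this nitrogen, a 1.1-fold lower number from compound 1 to compound 3 (0.06 log units; within the scatter) and a 1.2-fold higher number from compound 2 to compound 3 (0.08 log units; within the scatter), swap one alkyl for another, and a 1.4-fold lower number from compound 1 to compound 2 (0.14 log units; within the scatter) extends a chain; each stays within scatter. None puts a carbonyl or an aromatic ring on that nitrogen, so nothing measured resembles the present change and no direction can be read from it. Compound 4 is therefore expected to stay in the same region, a step of a 1.1-fold higher number from compound 3 to compound 4 (0.04 log units; within the scatter) in this assay. Compound 4 is estimated at 3000 nM, with a deliberately wide range from 800 nM to 12000 nM.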

Compound 4, half-maximal inhibitory concentration: 12300 nM
Compound 4: the middle estimate sits 4.1-fold (0.61 log units) below what was measured; measured number above the stated range.
By their numbers in this assay, from the lowest: compounds 2, 3 and 1 (each within the scatter of the next); then compound 4.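

At the aromatic nitrogen the alkyl swaps stay within the scatter, whereas (thiophen-2-yl)carbonyl is the only group shown that moves the number in this assay beyond it: a 4.5-fold higher number from compound 3 to compound 4 (0.65 log units; beyond the scatter), a 5.4-fold higher number from compound 2 to compound 4 (0.73 log units; beyond the scatter) and a 3.9-fold higher number from compound 1 to compound 4 (0.59 log units; beyond the scatter). This position is therefore not indifferent to its substituent, and this acyl group gives a weaker inhibitor than all three alkyl groups. Nothing available accounts for the shift. The carbonyl and the thiophen-2-yl ring enter together, and their shares remain unseparated. Benzyl or acetyl on the same nitrogen would pull them apart.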